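The compounds below may be only part of what the source reports. "The series", "measured", "known", "first", "only" and "open" are said of these compounds alone.

Working notes on the series. In an assay on THP-1 cells for displacement of a labelled ligand from C-C chemokine receptor type 1 (Homo sapiens) (on this read-out lower numbers stand for stronger inhibition and higher numbers for weaker inhibition), compound 1 `CC(C)[C@@H](NC(=O)c1cc2ccccc2s1)C(=O)N1CCC(c2ccc(Cl)cc2)CC1` gives 58 nM, the second highest of the three numbers in hand. Compound 3 `CC[C@@H](C)[C@@H](NC(=O)CC(C)C)C(=O)N1CCC(c2ccc(Cl)cc2)CC1` gives 34 nM, within the scatter of compound 1, whereas compound 2 `CC(C)C(NC(=O)c1ccccc1)C(=O)N1CCN(c2ccc(Cl)cc2)CC1` gives 525 nM, a gap beyond the scatter. Compound 4 `CC(C)[C@@H](NC(=O)NCc1ccccc1)C(=O)N1CCC(c2ccc(Cl)cc2)CC1` awaits measurement in this assay; it differs from compound 1 by benzylamino in place of 1-benzothiophen-2-yl on a carbonyl carbon. For the measured compounds named here, no measured pair shows this change. A small acyl group on the same carbonyl is tolerated, because compound 3 gives 34 nM, so the step from compound 1 is expected to be a modest rise, a 2.1-fold higher number from compound 1 to compound 4 (0.32 log units; beyond the scatter), near the edge of the scatter. Compound 4 is expected to give 120 nM, in the range 40 nM to 400 nM.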

Compound 4, half-maximal inhibitory concentration: 180 nM
Compound 4: the middle estimate sits 1.5-fold (0.18 log units) below what was measured; the range from low to high includes it.
By their numbers in this assay, from the lowest: compounds 3 and 1 (each within the scatter of the next); then compound 4; then compound 2.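

The first step read at a single place, benzylamino in place of 1-benzothiophen-2-yl on a carbonyl carbon, gives a 3.1-fold higher number from compound 1 to compound 4 (0.49 log units; beyond the scatter) in this assay. This position therefore responds to the change, though the step is modest and compound 4 still gives a measurable value. Nothing in hand accounts for the step.

Open, from the compounds shown here alone, is whether the step follows from the nitrogen of benzylamino or from the absence of the five-membered aromatic ring. A benzyl or phenylamino group on the same carbonyl carbon would bear on that question.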